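Phenyl for 3-chlorobenzyl on an indazole-type nitrogen

The source may report more compounds than this note shows. Statements on the series, on what has been measured and on what is new or still open speak of the compounds shown alone.

Compound 1: `CCOC(=O)c1ccc(-c2nn(Cc3cccc(Cl)c3)c3ccccc23)cc1`, in a functional assay on cells (Platelet, Homo sapiens) for inhibition (a lower number here means a stronger inhibitor, a higher number a weaker inhibitor), gives > 10000 nM, which is a limit of the assay and not a number.
Compound 2: `O=C(O)c1ccc(-c2nn(Cc3ccccc3)c3ccccc23)cc1`, in this assay gives > 10000 nM, again a limit rather than a number.

For the measured compounds named here, compound 1 therefore stands at the weak end of what this assay can report, and so does the only other measured compound; both sit at the limit of > 10000 nM in this assay, at which 2 of the 2 values shown sit. Going by the values given here, no step between measured compounds can be sized from this, since neither value is a number.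

Compound 3, `CCOC(=O)c1ccc(-c2nn(-c3ccccc3)c3ccccc23)cc1`, has not been measured. It differs from compound 1 in one place: phenyl in place of 3-chlorobenzyl on an aromatic nitrogen. With both known values at the limit, there is no measured change to build on, and the expected step that the limit leaves unreadable from compound 1 to compound 3 is none beyond the scatter. Compound 3 is expected to give about 15000 nM, most likely between 5000 nM and 50000 nM, with a good chance that only a limit is reported.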

Compound 3, half-maximal inhibitory concentration: > 10000 nM
Compound 3: a limit, no number (the forecaster's own chance of this, stated with the estimate: 80%); the middle value lies beyond the limit too.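

Compound 1 and compound 3 both give a limit of the assay and not a number, so no step can be read between them: the limit of > 10000 nM in this assay, at which 3 of the 3 values shown sit.

The compounds shown leave open whether phenyl in place of 3-chlorobenzyl changes inhibition at all, and which change to the shared core would give a readable number.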